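Shortening the alkenyl chain of a hydrazide carbamate

This account rests on a few compounds, and the source may have more. Where it says the series, first, only, none or still open, it means among the compounds named here.

Of the compounds shown here, three have been measured so far in a functional assay on K562 cells (Homo sapiens) for antiproliferative activity, read by resazurin assay, with a stated time of 72 h; a higher number here means a weaker inhibitor of growth, a lower number a stronger inhibitor of growth. Compound 1, `CCCCCCCCCCCC/C=C\N(NC(=O)COC)C(=O)OC(C)(C)C`, gives 28300 nM. Compound 2, `CCCCCCCCCCCC/C=C\N(NC(C)=O)C(=O)CCCCCCCCC`, gives 41900 nM. Compound 3, `CCCCCCCCCCCC/C=C/N(NC(=O)COC)C(=O)OC(C)(C)C`, gives 41400 nM, the second highest of the three numbers, and all three numbers lie within the scatter of one another. Going by the values given here, the only single-point step among them is a 1.5-fold higher number from compound 1 to compound 3 (0.17 log units; within the scatter), which rests on the fact that compounds 1 and 3 differ only in the configuration as drawn and shows no change beyond the scatter.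

Compound 4, `CCCCCCCC/C=C/N(NC(=O)COC)C(=O)OC(C)(C)C`, is the next compound to be measured. It differs from compound 3 in one place: hydrogen in place of butyl on a saturated chain carbon, eight bonds along the chain from a double-bonded chain carbon. Put simply, the long saturated tail that hangs off the double bond is cut shorter by four carbons, while the rest of the molecule, including the methoxyacetyl hydrazide and the tert-butyl carbamate, stays the same.

Among the compounds with values here, no measured step speaks to this change. Within the data shown here, the one step known, from compound 1 to compound 3, alters only the drawn geometry of the double bond and leaves the chain untouched, so it gives no guide to what a shorter chain does. Compound 2 carries a different acyl group and a different tail at the same time, so its value cannot be separated into a chain effect.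

With nothing to anchor the step, compound 4 is estimated to give about 60000 nM in this assay, with a plausible range from 25000 nM to 150000 nM. This means an expected step of a 1.4-fold higher number from compound 3 to compound 4 (0.16 log units; within the scatter), leaning toward a somewhat higher number, though a result within the scatter of compound 3 would not be surprising.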

Compound 4, concentration for 50% growth inhibition: 45000 nM
The estimate for compound 4 lay 1.3-fold (0.12 log units) above the measured number; the range from low to high includes it.
By their numbers in this assay, from the lowest: compounds 1, 3, 2 and 4 (each within the scatter of the next).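

In this assay, putting hydrogen in place of butyl on a saturated chain carbon, eight bonds along the chain from a double-bonded chain carbon, gives a 1.1-fold higher number from compound 3 to compound 4 (0.04 log units; within the scatter). Going by these compounds alone, this is the first measured step that touches the tail rather than the drawn geometry of the double bond, and it shows that, with the methoxyacetyl hydrazide and the tert-butyl carbamate kept in place, the butyl portion can be removed without a change beyond the scatter. Nothing measured here offers an explanation for this outcome.

A single step on a single tail cannot show how far the chain can be trimmed, so a tail cut further, to propyl or ethyl, or a longer chain than that of compound 3, could behave differently. Also open, on these data alone, are whether an amine or a carboxylic acid at the end of the tail would move the number beyond the scatter, and whether the same shortening gives the same result with the double bond drawn Z, as in compound 1.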